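The compounds below may be only part of what the source reports. "The series", "measured", "known", "first", "only" and "open" are said of these compounds alone.

In a functional assay on HepG2 cells (Homo sapiens) for antiproliferative activity, read by MTT assay, with a stated time of 24 h (a higher number here means a weaker inhibitor, a lower number a stronger inhibitor), compound 1 `COc1cc(OC)c(-c2coc3cc(OCc4ccccc4)ccc3c2=O)cc1OC` gives 1320 nM and compound 2 `COc1cc(OC)c(-c2coc3cc(OCc4ccc(C#N)cc4)ccc3c2=O)cc1OC` gives the higher number of the two (4230 nM). Compound 3 `COc1cc(OC)c(-c2coc3cc(OCc4cccc(Cl)c4)ccc3c2=O)cc1OC` differs from compound 2 by 3-chlorophenyl in place of 4-cyanophenyl on a saturated chain carbon bound to an oxygen on an aromatic ring with 3-chlorophenyl in place of 4-cyanophenyl. Going by the values given here, the only measured step bearing on this is modest and beyond the scatter (a 3.2-fold higher number from compound 1 to compound 2 (0.51 log units; beyond the scatter)), for cyano in place of hydrogen on an aromatic carbon. Among the compounds with values here, compound 3 carries no cyano, and no measured compound carries chlorine. On that single step, a modest move to a lower number in this assay is expected (a 2.1-fold lower number from compound 2 to compound 3 (0.33 log units; beyond the scatter)). For compound 3 the estimate is 2000 nM within an expected range (800 nM to 5000 nM).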

Compound 3, half-maximal inhibitory concentration: 750 nM
Beside the measured number, compound 3's estimate is 2.7-fold (0.43 log units) above it, and the stated range ends above it.
By their numbers in this assay, from the lowest: compounds 3 and 1 (each within the scatter of the next); then compound 2.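

In this assay, the change from 4-cyanobenzyl to 3-chlorobenzyl gives a 5.6-fold lower number from compound 2 to compound 3 (0.75 log units; beyond the scatter) at this position, so the substituent on this aromatic ring clearly affects the read-out. Chloro in place of hydrogen gives a 1.8-fold lower number from compound 1 to compound 3 (0.25 log units; within the scatter) and leaves compound 3 and compound 1 unseparated, so of these three only compound 2 stands apart. No measurement here accounts for the gap between compound 2 and compound 3. The step from compound 2 to compound 3 changes both the group and its ring position, leaving their contributions unresolved. Open too, from the compounds shown here alone, is how an amine or a carboxylic acid on this ring would read.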